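A Larger Swap on a Flat Cytotoxicity Series

A few compounds are considered here, and "the series" means these few. Any claim that something is new, unique, unknown or untested is made for them only; others in the source may bear on it.

In a functional assay on HepG2 cells (Homo sapiens) for cytotoxicity, read by MTT assay, with a stated time of 72 h (on this read-out higher numbers stand for weaker inhibition and lower numbers for stronger inhibition), compound 1 `O=C(N/N=C/c1ccc(F)cc1Cl)Nc1cc2c(Nc3ccc(F)c(Cl)c3)ncnc2cc1O[C@H]1CCOC1` gives 26100 nM, compound 2 `O=C(N/N=C/c1cccc(Cl)c1Cl)Nc1cc2c(Nc3ccc(F)c(Cl)c3)ncnc2cc1O[C@H]1CCOC1` gives 16900 nM and compound 3 `COc1cc2ncnc(Nc3ccc(F)c(Cl)c3)c2cc1NC(=O)N/N=C/c1cccc(Cl)c1Cl` gives 26100 nM. Compound 3 is thus level with compound 1, and all three values lie within the scatter of one another. Compound 4 `CCN(CC)c1ccc(/C=N/NC(=O)Nc2cc3c(Nc4ccc(F)c(Cl)c4)ncnc3cc2OC)c(O)c1` departs from compound 3 at the carbon with a double bond to nitrogen, carrying 4-(diethylamino)-2-hydroxyphenyl in place of 2,3-dichlorophenyl on a carbon with a double bond to nitrogen. The closest evidence is a 1.5-fold lower number from compound 1 to compound 2 (0.19 log units; within the scatter), which exchanged one halogenated phenyl group for another at that same place and stayed within the scatter. The step of a 1.5-fold higher number from compound 2 to compound 3 (0.19 log units; within the scatter) changed the group on an oxygen on an aromatic ring instead, and it too stayed within the scatter. Neither step tests a group like the incoming one, so the forecast is weakly supported. The expected change in this assay is modest, namely a 2.2-fold lower number from compound 3 to compound 4 (0.34 log units; beyond the scatter). Compound 4 is estimated at 12000 nM, with an expected range from 3000 nM to 35000 nM.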

Compound 4, half-maximal inhibitory concentration: 29300 nM
Compound 4: the middle estimate sits 2.4-fold (0.39 log units) below what was measured; measured number inside the range.
By their numbers in this assay, from the lowest: compounds 2, 1, 3 and 4 (each within the scatter of the next).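

At the carbon with a double bond to nitrogen, 4-(diethylamino)-2-hydroxyphenyl in place of 2,3-dichlorophenyl gives a 1.1-fold higher number from compound 3 to compound 4 (0.05 log units; within the scatter) in this assay for this swap. The earlier step at this place only exchanged one halogenated phenyl group for another, whereas here the incoming group has no chlorine, has more heavy atoms and brings a hydrogen-bond donor and hydrogen-bond acceptors that the leaving group lacks, yet the two compounds stay within the scatter of each other. Nothing measured in this series accounts for that result.

On these data alone, the hydroxy and diethylamino groups enter together, so what each contributes alone remains open. Also open, as far as these compounds go, is whether a carboxylic acid or a primary amine on the phenyl ring at this place would give a step beyond the scatter.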